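The source may report more compounds than this note shows. Statements on the series, on what has been measured and on what is new or still open speak of the compounds shown alone.

Measured so far in a functional assay on MCF7 cells (Homo sapiens) for antiproliferative activity, read by MTT assay, with a stated time of 48 h; a higher number here means a weaker inhibitor, a lower number a stronger inhibitor:

Compound 1 `O=[N+]([O-])c1cccc(-c2nn(-c3ccccc3)cc2C(Nc2nc3ccccc3s2)c2c(O)ccc3ccccc23)c1` gives 43900 nM
Compound 2 `Cc1ccc2nc(NC(c3cn(-c4ccccc4)nc3-c3cccc([N+](=O)[O-])c3)c3c(O)ccc4ccccc34)sc2c1` gives 38400 nM
Compound 3 `Cc1ccc(-c2nn(-c3ccccc3)cc2C(Nc2nc3cc(C)c(C)cc3s2)c2c(O)ccc3ccccc23)cc1` gives 22400 nM

These three values lie within the usual scatter of one another, so compound 1 does not stand apart from the others. Compound 4 `Oc1ccc2ccccc2c1C(Nc1nc2ccccc2s1)c1cn(-c2ccccc2)nc1-c1ccccc1` differs from compound 1 by hydrogen in place of nitro on an aromatic carbon. For the measured compounds named here, no measured step makes this change. Going by the values given here, the one step available, a 1.1-fold lower number from compound 1 to compound 2 (0.06 log units; within the scatter), is a different change and stays within the scatter. Compound 3 also lacks nitro, though it differs in other places too, and at 22400 nM it remains within the scatter of compound 1. No step beyond the scatter is therefore expected, and the expected step is a 1.5-fold lower number from compound 1 to compound 4 (0.17 log units; within the scatter) in this measurement. Compound 4 is estimated at 30000 nM, with an expected range of 13000 nM to 70000 nM overall.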

Compound 4, half-maximal inhibitory concentration: 48900 nM
Estimate against measurement, compound 4: 1.6-fold (0.21 log units) below; low and high end bracket the measured number.
By their numbers in this assay, from the lowest: compounds 3, 2, 1 and 4 (each within the scatter of the next, the first and the last beyond it).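

In this assay, the change from 3-nitrophenyl to phenyl gives a 1.1-fold higher number from compound 1 to compound 4 (0.05 log units; within the scatter) and so shows directly that hydrogen in place of nitro on this aromatic carbon leaves the number within the scatter. The earlier compounds shown here could not show this, since compound 3 also lacks nitro but differs in other places too. No evidence is available that bears on this result. The compounds shown leave open whether an amine or a carboxylic acid on this aromatic carbon would give a step beyond the scatter.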